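This account rests on a few compounds, and the source may have more. Where it says the series, first, only, none or still open, it means among the compounds named here.

Within the data shown here, in a functional assay (mast cells) for inhibition, with Rattus norvegicus as the target (a lower number here means that less compound is needed, a higher number that more compound is needed for the effect), compound 1 (`CCOc1ccc(N/N=C2\CCC(C)n3c2ncc(C(=O)O)c3=O)cc1`) gives 17600 nM and compound 2 (`CCOc1ccc(N/N=C2\CC[C@H](C)n3c2ncc(C(=O)O)c3=O)cc1`) gives 19200 nM in the same test, so compound 1 stands level with the only other measured compound, within the scatter. Compound 3 (`CC1CC/C(=N\Nc2ccc(C(=O)O)cc2)c2ncc(C(=O)O)c(=O)n21`) keeps the core of compound 1 but carries carboxy in place of ethoxy on an aromatic carbon, para to a large group (carboxy in place of ethoxy on an aromatic carbon). Among the measured compounds shown here, the one measured step offers little guidance here. That step, a 1.1-fold higher number from compound 1 to compound 2 (0.04 log units; within the scatter), lies within the scatter and concerns only (the fact that one of compounds 1 and 2 is drawn with a defined configuration and the other without, at the place where they differ), at a different place from the one changing now. For the measured compounds named here, no measured compound varies the ethoxy group, so the data give neither a size nor a direction for this replacement. The expected step of a 1.0-fold higher number from compound 1 to compound 3 (0.01 log units; within the scatter) is therefore no change beyond the scatter in this assay, although this is a default rather than a trend and the margins must stay wide. For compound 3 the estimated value is 18000 nM, with an expected range from 3500 nM to 90000 nM in this test.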

Compound 3, half-maximal effective concentration: 1000000 nM
Compound 3: middle estimate off by 56-fold (1.74 log units), on the low side; measured number outside the range, above it.
By their numbers in this assay, from the lowest: compounds 1 and 2 (each within the scatter of the next); then compound 3.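

In this assay, among these compounds, the ethoxy position on the aromatic carbon is the only place in these compounds where a change moves the number beyond the scatter: carboxy in place of ethoxy gives a 57-fold higher number from compound 1 to compound 3 (1.75 log units; beyond the scatter). Among the compounds shown here, this shows that the position, para to a large group on a six-membered aromatic ring of carbon only, is far from indifferent to the group it carries, which the only earlier step, a 1.1-fold higher number from compound 1 to compound 2 (0.04 log units; within the scatter), could not show because it concerned another place and left the two numbers level. The step also gives this replacement a direction and a size, but nothing measured here explains why the number rises so far.

The compounds shown leave open whether this large rise is specific to the carboxylic acid or would also follow from another group at this position, such as a methyl ester of that acid, a methoxy group, an amine or a longer alkoxy chain. They also leave open whether the same replacement would give a step of similar size on compound 2, with its stereocentre drawn as S.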